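The source may report more compounds than this note shows. Statements on the series, on what has been measured and on what is new or still open speak of the compounds shown alone.

Measured in a functional assay on HL-60 cells (Homo sapiens) for antiproliferative activity, read by MTT assay; on this read-out higher numbers stand for weaker inhibition and lower numbers for stronger inhibition:
- compound 1 `C=C[C@H]1O[C@H](COCc2ccccc2)[C@@H](OCc2ccccc2)[C@H](OCc2ccccc2)[C@H]1O`: "not active" (no number reported)
- compound 2 `CCC[C@H]1O[C@H](COCc2ccccc2)[C@@H](OCc2ccccc2)[C@H](OCc2ccccc2)[C@H]1O`: 28200 nM

Among the compounds with values here, compound 2 holds the only number in this assay, and compound 1 gave none. Compound 3 `O[C@H]1CO[C@H](COCc2ccccc2)[C@@H](OCc2ccccc2)[C@@H]1OCc1ccccc1` is reached from compound 2 by hydrogen in place of propyl on a saturated ring carbon. Within the data shown here, no measured step exists to size this change against. The expected step, a 1.2-fold higher number from compound 2 to compound 3 (0.09 log units; within the scatter), stays within the scatter, leaning if anything towards weaker inhibition, and a result without a number would not be surprising. For compound 3 the estimated value is 35000 nM, with an expected range of 12000 nM to 100000 nM.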

Compound 3, half-maximal inhibitory concentration: "not active" (no number reported)
Nothing numeric was reported for compound 3; the estimate stays without a comparison.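

Within the data shown here, compound 3 gave "not active" (no number reported) in this assay, so no step from compound 2 can be read. How much the propyl group of compound 2 contributes to its inhibition stays open, and nothing shown bears on the cause of this result.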